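Adding a 4-fluorophenyl group to compound 3

The compounds below may be only part of what the source reports. "The series", "measured", "known", "first", "only" and "open" are said of these compounds alone.

In a physicochemical assay for lipophilicity, using the shake flask method, in phosphate buffer, measured as octanol-water partition, with a stated time of 24 h, at pH 7.4 (a higher number here means a more lipophilic compound, a lower number a more polar compound), compound 3 (`Cc1nn(-c2ccccc2F)c2c1CCS(=O)(=O)O2`) gives 1.86 and is the lowest of three measured compounds. Compound 1 (`Cc1cc(C2CS(=O)(=O)Oc3c2c(C2CC2)nn3-c2ccccc2Cl)ccc1Br`) gives 2.53 and compound 2 (`O=S1(=O)CC(c2cccc(F)c2)c2c(C3CC3)nn(-c3ccccc3F)c2O1`) gives 2.86 and both numbers lie beyond the scatter from compound 3.

Compound 4 (`Cc1nn(-c2ccccc2F)c2c1C(c1ccc(F)cc1)CS(=O)(=O)O2`) has not yet been measured. It differs from compound 3 by a single change (4-fluorophenyl in place of hydrogen on a saturated ring carbon): 4-fluorophenyl in place of hydrogen on a saturated ring carbon. Going by the values given here, no measured pair shows this change alone, so any forecast is indirect. The nearest guide is compound 2 (2.86), which also has a fluorophenyl group on that ring carbon but differs from compound 4 elsewhere as well. On that rough basis, a rise beyond the scatter is expected in this assay and the estimated step is a number 0.74 log units higher from compound 3 to compound 4 (beyond the scatter) in the upward direction. Compound 4 is expected to read 2.6 with an estimated range (2.2 to 3).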

Compound 4, partition coefficient: 2.13
For compound 4 the middle estimate is 0.47 log units above the measured one; the whole stated range lies above it.
By their numbers in this assay, from the lowest: compounds 3 and 4 (each within the scatter of the next); then compound 1; then compound 2.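

This result gives the first view of a single change on its own: with 4-fluorophenyl in place of hydrogen on a saturated ring carbon, the step in this assay is a number 0.27 log units higher from compound 3 to compound 4 (within the scatter) and the two numbers cannot be told apart. Going by these compounds alone, this ring carbon can therefore carry an added aromatic ring of 7 heavy atoms while the number stays within the usual spread of repeats, something the earlier compounds, which differ in several places at once, could not show. Nothing available here explains why the step is this small.

As far as these compounds go, whether other groups on this ring carbon, such as an amine or a carboxylic acid, would also stay this close to compound 3 remains open. So does whether the same change gives a similar step when the rest of the molecule differs, for example with cyclopropyl in place of the methyl group of compound 3.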